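The source may report more compounds than this note shows. Statements on the series, on what has been measured and on what is new or still open speak of the compounds shown alone.

Measured compounds in this series:
compound 1 `CC1(C)C=C(n2ccccc2=O)c2cc(S(=O)(=O)NCCO)ccc2O1` gives 87.9%
compound 2 `COc1ccc(NS(=O)(=O)c2ccc3c(c2)C(n2ccccc2=O)=CC(C)(C)O3)cc1` gives 84.2%
compound 3 `CC1(C)C=C(n2ccccc2=O)c2cc(S(=O)(=O)c3ccccc3)ccc2O1` gives 88.1%

In a functional assay on the whole organism (trachea) with Rattus norvegicus as the target (on this read-out higher numbers stand for larger maximal responses and lower numbers for smaller maximal responses), compound 2 holds the lowest of the three numbers, yet the steps of a number 3.7 percentage points lower from compound 1 to compound 2 (within the scatter) and a number 3.9 percentage points higher from compound 2 to compound 3 (within the scatter) both sit within the scatter, so the three sit on one level. Compound 4 `CC1(C)C=C(n2ccccc2=O)c2cc(S(=O)(=O)Oc3ccccc3)ccc2O1` differs from compound 2 by phenoxy in place of (4-methoxyphenyl)amino on a sulfonyl sulfur. The step that bears on this is a number 3.9 percentage points higher from compound 2 to compound 3 (within the scatter), where the same group is exchanged at the same sulfonyl sulfur without leaving the scatter; a number 0.2 percentage points higher from compound 1 to compound 3 (within the scatter) points the same way. The change to compound 4 is therefore expected to give no step beyond the scatter in this assay, the estimated step being a number 2.8 percentage points higher from compound 2 to compound 4 (within the scatter). Compound 4 is expected at 87%, within 78% to 95%.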

Compound 4, largest response reached (Emax), in percent of the reference or control that the assay uses: 86.7%
For compound 4 the middle estimate is 0.3 percentage points above the measured one, and the stated range covers the measured number.
By their numbers in this assay, from the lowest: compounds 2, 4, 1 and 3 (each within the scatter of the next).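

At the sulfonyl sulfur, phenoxy sits on the same level as the other three groups in this assay: a number 2.5 percentage points higher from compound 2 to compound 4 (within the scatter), a number 1.4 percentage points lower from compound 3 to compound 4 (within the scatter) and a number 1.2 percentage points lower from compound 1 to compound 4 (within the scatter). Linking the aromatic ring to the sulfur through oxygen, with no hydrogen-bond donor in the entering group, therefore gives no step beyond the scatter from the amino-linked or directly linked groups. No supporting data explain this flat result. On these data alone, whether a carboxylic acid or a longer alkyl chain on the sulfonyl sulfur would leave this level remains open.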